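Replacing iodine with a trifluoromethylphenyl arm on the amide

This account rests on a few compounds, and the source may have more. Where it says the series, first, only, none or still open, it means among the compounds named here.

Compound 1, `O=C(CCc1cccc2c1B(O)OC2)Nc1nccs1`: in a functional assay on HCT-116 cells (Homo sapiens) for antiproliferative activity, read by MTT assay, with a stated time of 72 h (a higher number here means a weaker inhibitor, a lower number a stronger inhibitor), compound 1 gives > 100000 nM, which is a limit of the assay rather than a number.
Compound 2, `O=C(CCc1cccc2c1B(O)OC2)Nc1ccc(Cl)cc1`: in this assay compound 2 gives 12000 nM.
Compound 3, `O=C(CCc1cccc2c1B(O)OC2)Nc1cccc(I)c1`: in this assay compound 3 gives 2300 nM.

Compound 3 stands lowest among the numbers shown, with compound 2 nearest: a 5.2-fold lower number from compound 2 to compound 3 (0.72 log units; beyond the scatter). Compound 4, `O=C(CCc1cccc2c1B(O)OC2)Nc1cccc(-c2ccc(C(F)(F)F)cc2)c1`, differs from compound 3 in one place: 4-(trifluoromethyl)phenyl in place of iodo on an aromatic carbon. The measured steps that bear on this all swap the group on the amide-type nitrogen: an at least 8.3-fold lower number from compound 1 to compound 2 (0.92 log units; beyond the scatter), an at least 43-fold lower number from compound 1 to compound 3 (1.63 log units; beyond the scatter) and a 5.2-fold lower number from compound 2 to compound 3 (0.72 log units; beyond the scatter). Every such swap so far lowered the number, but the group entering compound 4 is much larger than anything yet measured, so its effect is uncertain. A small lowering is expected in this assay. For compound 4 the estimate is 1500 nM, between 300 nM and 8000 nM, an expected 1.5-fold lower number from compound 3 to compound 4 (0.19 log units; within the scatter).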

Compound 4, half-maximal inhibitory concentration: 550 nM
Estimate against measurement, compound 4: 2.7-fold (0.44 log units) above; the range from low to high includes it.
By their numbers in this assay, from the lowest: compound 4; then compound 3; then compound 2. At a limit, above all of these: compound 1.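

In this assay, the step to a far larger arm gives a 4.2-fold lower number from compound 3 to compound 4 (0.62 log units; beyond the scatter), the first change shown on the aromatic ring rather than a swap of the whole group on the amide nitrogen. This place therefore accepts 4-(trifluoromethyl)phenyl, with its 10 heavy atoms and extra ring, in place of a single iodine, and the number still falls. Nothing measured here explains why the number falls.

On these data alone, whether the trifluoromethyl matters, or the new ring alone is enough, stays open. So does the outcome with a plain phenyl, an amine or a carboxylic acid at this place.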